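A few compounds are considered here, and "the series" means these few. Any claim that something is new, unique, unknown or untested is made for them only; others in the source may bear on it.

Measured compounds:
compound 1 `COc1ccc(C2=NN(c3ccccc3)C(c3ccc(C)cc3)C2S(=O)(=O)CC2=NCCO2)cc1` — 62.5%
compound 2 `O=S(=O)(CC1=NCCO1)C1=NNCC1c1ccccc1` — "not active" (no number reported)
compound 3 `O=S(=O)(CC1=NCCS1)C1=NNCC1c1ccccc1` — "not active" (no number reported)

In a functional assay, tested at 50 ug/mL (on this read-out lower numbers stand for a weaker effect and higher numbers for a stronger effect at the one concentration tested), compound 1 gives 62.5%. Compound 2 is reported in this assay only as "not active" (no number reported), without a number, and compound 3 is reported the same way, as "not active" (no number reported). Compound 2 therefore stands among the entries for which no single number is given; the one number shown belongs to compound 1, which differs from compound 2 in more than one place. Compound 4 `O=S(=O)(CC1=NCCO1)C1=NNCC1c1ccc(Cl)cc1` has not yet been measured in this assay. It differs from compound 2 in one place: chloro in place of hydrogen on an aromatic carbon. For the measured compounds named here, no step between measured compounds is available, so the size of this change cannot be read from the data; a small step, in either direction or none beyond the scatter, is expected. The read-out for compound 4 in this assay is estimated at 15%, between 0% and 35%.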

Compound 4, a percentage reported as activity, at one concentration (the size of the read-out at that concentration, not a potency): "not active" (no number reported)
For compound 4 the study gives words and no number; there is nothing to compare the estimate with.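

In this assay compound 2 and compound 4 are both reported without a number, so no step can be read between them. The compounds shown leave open whether chloro in place of hydrogen changes this read-out at all. No evidence on a cause is available.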